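Trading a Phenyl for an Ethyl on a Shared Core

The compounds below may be only part of what the source reports. "The series", "measured", "known", "first", "only" and "open" are said of these compounds alone.

Of the compounds shown here, three built on one shared core have been tested in a functional assay for antagonist activity at Neuropeptides B/W receptor type 1 (Homo sapiens), read by cAMP accumulation; on this read-out lower numbers stand for stronger inhibition and higher numbers for weaker inhibition. Compound 1, with the structure `CC(=O)c1ccccc1-c1nc2cc([N+](=O)[O-])ccc2[nH]1`, reaches only the limit of the assay, giving > 31600 nM. Compound 2, with the structure `CC(=O)c1cccc(-c2nc3cc([N+](=O)[O-])ccc3[nH]2)c1`, likewise gives only a limit, > 31600 nM. For the measured compounds named here, compound 3, with the structure `O=[N+]([O-])c1ccc2[nH]c(-c3ccc(-c4ccccc4)cc3)nc2c1`, is the one compound that yields a number: in this assay compound 3 gives 4880 nM. Going by the values given here, this is the only number among the three values, since the other two sit at the limit of > 31600 nM in this assay, at which 2 of the 3 values shown sit.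

Compound 4, with the structure `CCc1ccc(-c2nc3cc([N+](=O)[O-])ccc3[nH]2)cc1`, has not yet been measured. It differs from compound 3 in one place: ethyl in place of phenyl on an aromatic carbon. Among the compounds with values here, no measured pair differs by this kind of change, so the size of the step is open. A loss of potency going beyond the scatter is expected, which is a step of a 3.1-fold higher number from compound 3 to compound 4 (0.49 log units; beyond the scatter). Compound 4 is therefore estimated at 15000 nM, between 4000 nM and 50000 nM, with a real chance that only a limit is reported.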

Compound 4, half-maximal inhibitory concentration: 1020 nM
Estimate against measurement, compound 4: 15-fold (1.17 log units) above, outside the stated range (below it).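

In this assay, ethyl in place of phenyl gives a 4.8-fold lower number from compound 3 to compound 4 (0.68 log units; beyond the scatter), so at this position the smaller group with no ring inhibits more strongly than the phenyl it replaces. The second aromatic ring of compound 3 is therefore not needed for activity on the shared core, and removing it improves the result rather than losing it. The earlier compounds offered no such number-to-number comparison, and two of them give only a limit: the limit of > 31600 nM in this assay, at which 2 of the 4 values shown sit.

From the compounds shown here alone, with just two groups compared at this place, it remains open whether a methyl, a longer chain such as propyl or butyl, or an amine would lower the number further or raise it again. Going by these compounds, what makes ethyl better than phenyl here also stays open, since a single step cannot separate the loss of the ring from the change in size.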